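A few compounds are considered here, and "the series" means these few. Any claim that something is new, unique, unknown or untested is made for them only; others in the source may bear on it.

Measured in an ADME assay on HepG2 cells (Homo sapiens) for cytotoxicity, read by CellTiter-Glo and resazurin assay, with a stated time of 72 h (on this read-out lower numbers stand for an effect already at smaller amounts and higher numbers for an effect only at larger amounts of compound), where every entry is a limit of the assay and not a number:

compound 1 `CC(C)N(Cc1cccc(OCCCCCC(=O)O)c1)C(=O)c1ccc(-c2ccco2)cc1` gives > 26000 nM (a limit)
compound 2 `CC(C)N(Cc1cccc(OCCCCCC(=O)O)c1)C(=O)c1ccc(-c2ccc3cc[nH]c3c2)cc1` gives > 26000 nM (a limit)
compound 3 `CC(C)N(Cc1cccc(OCCCCCC(=O)O)c1)C(=O)c1ccc(-c2cccc(OC(F)(F)F)c2)cc1` gives > 26000 nM (a limit)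

Compound 3 has no exact number to its name. In this assay compound 3 stands at > 26000 nM as a limit, and the two other values are limits too. All the data hold so far is the limit of > 26000 nM in this assay, at which 3 of the 3 values shown sit, and nothing finer.

Compound 4 `CC(C)N(Cc1cccc(OCCCCCC(=O)O)c1)C(=O)c1ccc(-c2cccc(Cl)c2)cc1` differs from compound 3 in one place, with chloro in place of trifluoromethoxy on an aromatic carbon of a six-membered aromatic ring of carbon only, meta to a large group.

Among the measured compounds shown here, three measured steps bear on this change, each a swap of one group on an aromatic carbon. They are a step that the two limits leave unreadable from compound 1 to compound 3 and a step that the two limits leave unreadable from compound 2 to compound 3 and a step that the two limits leave unreadable from compound 1 to compound 2 and so none of them offers a size to carry over. For the measured compounds named here, with compound 1, compound 2 and compound 3 all sharing the limit of > 26000 nM in this assay, at which 3 of the 3 values shown sit, as their only reading, no step beyond the usual scatter is expected in this assay and no direction can be named. The estimated step is a step that the limit leaves unreadable from compound 3 to compound 4 and this is expected to mean no real move. For compound 4 the estimate is 30000 nM with an expected range from 15000 nM to 60000 nM and another limit is the most likely report.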

Compound 4, half-maximal effective concentration: > 21900 nM
Compound 4: only a limit was reported; the forecaster's own chance of this, stated with the estimate: 85%; the middle value does not contradict the limit.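

In this assay compound 4 gives > 21900 nM, which is a limit and not a number. Compound 1, compound 2 and compound 3 also carry only limits, so the steps from each of them to compound 4 cannot be read. The compounds shown leave open at what concentration, if any, each of the four would reach a half-maximal effect on these cells.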